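Aryl amide variation on the shared core

The source may report more compounds than this note shows. Statements on the series, on what has been measured and on what is new or still open speak of the compounds shown alone.

compound 1 `COc1ccc2c(=O)c(/C=C/C(=O)Nc3cccc(Cl)c3)coc2c1`: > 100000 nM
compound 2 `COc1ccc2c(=O)c(/C=C/C(=O)Nc3ccccc3)coc2c1`: 9050 nM
compound 3 `COc1ccc2c(=O)c(/C=C/C(=O)Nc3ccccc3OC)coc2c1`: 32300 nM

In a functional assay on Huh-7 cells (Homo sapiens) for inhibition, read by MTT assay, with a stated time of 48 h (on this read-out higher numbers stand for weaker inhibition and lower numbers for stronger inhibition), compound 1 gives only a limit, > 100000 nM, which is the assay limit of > 100000 nM in this assay, at which 1 of the 3 values shown sits, rather than a measured number. Compound 1 therefore stands at the weak end of the three values shown. Compound 2 gives 9050 nM in this assay. Compound 3 gives 32300 nM in this assay.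

Two steps start from compound 1. Replacing chloro with hydrogen on an aromatic carbon gives an at least 11-fold lower number from compound 1 to compound 2 (1.04 log units; beyond the scatter). Replacing 3-chlorophenyl with 2-methoxyphenyl on the amide-type nitrogen gives an at least 3.0-fold lower number from compound 1 to compound 3 (0.49 log units; beyond the scatter). Between the two better compounds, adding methoxy on an aromatic carbon gives a 3.6-fold higher number from compound 2 to compound 3 (0.55 log units; beyond the scatter).

Compound 4 `COc1ccc2c(=O)c(/C=C/C(=O)Nc3ccccc3C)coc2c1` is not yet measured. It differs from compound 1 by 2-methylphenyl in place of 3-chlorophenyl on an amide-type nitrogen. Both measured steps away from compound 1 lowered the number beyond the scatter, while the substituent added from compound 2 to compound 3 raised it; 2-methylphenyl occupies the place that 2-methoxyphenyl takes in compound 3. A lower number than the limit of compound 1, beyond the scatter, is therefore expected in this assay, most likely near compound 3. Compound 4 is expected at 25000 nM, within 8000 nM to 90000 nM, a step of an at least 4.0-fold lower number from compound 1 to compound 4 (0.60 log units; beyond the scatter).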

Compound 4, half-maximal inhibitory concentration: 26900 nM
For compound 4 the middle estimate is 1.1-fold (0.03 log units) below the measured one, within the range that was stated.
By their numbers in this assay, from the lowest: compound 2; then compounds 4 and 3 (each within the scatter of the next). At a limit, above all of these: compound 1.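

Exchanging methoxy for methyl on the aromatic carbon gives a 1.2-fold lower number from compound 3 to compound 4 (0.08 log units; within the scatter) in this assay, so compound 3 and compound 4 are not told apart at this place. With a 3.0-fold higher number from compound 2 to compound 4 (0.47 log units; beyond the scatter) beside a 3.6-fold higher number from compound 2 to compound 3 (0.55 log units; beyond the scatter), the 2-methylphenyl amide is a second case in which a group on this aromatic ring sits apart from the plain phenyl amide of compound 2. The change from 3-chlorophenyl to 2-methylphenyl gives an at least 3.7-fold lower number from compound 1 to compound 4 (0.57 log units; beyond the scatter), a step measured only against a limit for compound 1: the limit of > 100000 nM in this assay, at which 1 of the 4 values shown sits.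

The compounds shown leave open whether the limit of compound 1 follows the chloro group or where it sits, which a 2-chlorophenyl or 3-methylphenyl amide would separate. From the compounds shown here alone, how an amine or a carboxylic acid on this aromatic ring would read also remains open.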